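The source may report more compounds than this note shows. Statements on the series, on what has been measured and on what is new or still open speak of the compounds shown alone.

In a functional assay on HCT-116 cells (Homo sapiens) for cytotoxicity, read by MTT assay, with a stated time of 72 h (on this read-out higher numbers stand for weaker inhibition and lower numbers for stronger inhibition), the measured compounds read:

Compound 1 `COc1ccc(Nc2nc3ccccc3nc2S(=O)(=O)c2ccccc2)cc1`: 2420 nM
Compound 2 `COc1ccc(Nc2nc3ccccc3nc2S(=O)(=O)c2ccc(C)cc2)cc1`: > 50000 nM, a limit of the assay
Compound 3 `COc1ccc(Nc2nc3ccccc3nc2S(=O)(=O)c2ccc(OC)cc2)cc1`: 29100 nM

Compound 3, at 29100 nM, holds the higher of the two actual numbers, with compound 1 the nearest: a 12-fold higher number from compound 1 to compound 3 (1.08 log units; beyond the scatter). Compound 4 `COc1ccc(S(=O)(=O)c2nc3ccccc3nc2Nc2ccc(C(F)(F)F)cc2)cc1` differs from it by trifluoromethyl in place of methoxy on an aromatic carbon, para to a large group.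

Within the data shown here, no measured step makes this exchange. The large steps of an at least 20-fold higher number from compound 1 to compound 2 (1.31 log units; beyond the scatter) and a 12-fold higher number from compound 1 to compound 3 (1.08 log units; beyond the scatter) lie elsewhere on the molecule, and an at least 1.7-fold lower number from compound 2 to compound 3 (0.23 log units; that floor lies within the scatter) has a floor within the scatter. Compound 4 keeps the methoxy introduced in a 12-fold higher number from compound 1 to compound 3 (1.08 log units; beyond the scatter), so a high number is still expected, with no step beyond the scatter. The estimated step is a 1.5-fold lower number from compound 3 to compound 4 (0.16 log units; within the scatter). For compound 4 the expected value is 20000 nM, with an estimated range of 5000 nM to 50000 nM.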

Compound 4, half-maximal inhibitory concentration: 110 nM
Beside the measured number, compound 4's estimate is 180-fold (2.26 log units) above it; the measured number lies below the stated range.
By their numbers in this assay, from the lowest: compound 4; then compound 1; then compound 3. At a limit, above all of these: compound 2.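

The change from methoxy to trifluoromethyl, para to a large group, gives a 260-fold lower number from compound 3 to compound 4 (2.42 log units; beyond the scatter) in this assay. Compound 1, compound 2 and compound 3 all keep methoxy here, so this is the first change shown at this position and the first large step towards a lower number. Compound 4 reaches this while keeping the methoxy that came with a 12-fold higher number from compound 1 to compound 3 (1.08 log units; beyond the scatter) elsewhere on the molecule.

From the compounds shown here alone, how an amine or a nitrile would read at this position remains open, as does the size of this step without that other methoxy. Nothing shown accounts for the size of the step.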